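The source may hold more compounds than are shown below. What is called first, only, known or untested is meant among the compounds shown, and "the series" means these compounds.

Measured so far in an ADME assay on L6 cells (Rattus norvegicus) for cytotoxicity; a lower number here means a stronger inhibitor, a higher number a weaker inhibitor:
- compound 1 `Cc1ccc(N2CCN(C(=O)Cn3cnc([N+](=O)[O-])n3)CC2)cc1`: 148000 nM
- compound 2 `O=C(Cn1cnc([N+](=O)[O-])n1)N1CCN(c2ccc(Cl)cc2)CC1`: > 285000 nM

Compound 2 gives > 285000 nM, which is a limit of this assay and not a number. The series therefore has one value and one limit, and the position of compound 2 is not fixed by a number.

Compound 3 `O=C(Cn1cnc([N+](=O)[O-])n1)N1CCN(C(=O)C2CC2)CC1` is next, with this change from compound 2: cyclopropylcarbonyl in place of 4-chlorophenyl on an amine nitrogen in a ring. The 4-chlorophenyl leaves as a whole, and cyclopropylcarbonyl enters on the amine nitrogen in a ring.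

Among the measured compounds shown here, the only measured step is an at least 1.9-fold higher number from compound 1 to compound 2 (0.28 log units; that floor lies within the scatter). It gives a floor only and concerns a change on an aromatic carbon, so it bears on the new change only loosely. For the measured compounds named here, no measured step covers this replacement directly. The best remaining guide is compound 1 at 148000 nM, which suggests a similarly high number for compound 3. Compound 3 may quite possibly give a limit as well.

The expected change is a step that the limit leaves unreadable from compound 2 to compound 3, so no step beyond the scatter is expected. Compound 3 is estimated at 300000 nM, with an expected range from 120000 nM to 450000 nM.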

Compound 3, half-maximal inhibitory concentration: 156000 nM
Compound 3: the middle estimate sits 1.9-fold (0.28 log units) above what was measured; low and high end bracket the measured number.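

In this assay, the aromatic group on the amine nitrogen in a ring can give way to a group with no aromatic ring and a carbonyl without the read-out leaving the scatter, as cyclopropylcarbonyl in place of 4-methylphenyl gives a 1.1-fold higher number from compound 1 to compound 3 (0.02 log units; within the scatter). The replacement of 4-chlorophenyl by cyclopropylcarbonyl at the same place gives an at least 1.8-fold lower number from compound 2 to compound 3 (0.26 log units; that floor lies within the scatter), so it offers only a floor that lies within the scatter and fixes no size for this change. Compound 2 gives a limit and not a number, which leaves that comparison without a measured end point: the limit of > 285000 nM in this assay, at which 1 of the 3 values shown sits.

Whether any group on this nitrogen moves the number beyond the scatter remains open, since a benzyl group, a longer alkyl chain, an amine or a carboxylic acid in that place would test the position in ways that the three compounds shown do not. Also open, from the compounds shown here alone, is whether the flat response among the readable values holds once the shared core itself changes, for instance with an amine in place of the nitro group.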